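This account rests on a few compounds, and the source may have more. Where it says the series, first, only, none or still open, it means among the compounds named here.

Measured so far:
- Compound 1, `CCN(Cc1cccs1)C(=O)COc1ccc(C(=O)O)cc1`: "not active" (no number reported) in an assay on HEK293 cells for agonist activity at transient receptor potential cation channel subfamily M member 8 (Homo sapiens), read by fluorescence and calcium flux, with a stated time of 15 min; a lower number here means that less compound is needed, a higher number that more compound is needed for the effect
- Compound 2, `Cc1ccc(OCC(=O)N(Cc2cccs2)c2ncccn2)cc1`: 3700 nM
- Compound 3, `CCN(Cc1cccs1)C(=O)COc1ccc(F)cc1`: 422 nM

Compound 1 gave no number at all in this assay, only the word that it was inactive. Of the two compounds that did give a number, compound 2 has the higher one and compound 3 the lower one, and the gap between these two numbers is beyond the usual scatter of this kind of measurement. Compound 2 and compound 3 differ in more than one place, so the gap cannot be tied to any single change.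

The next compound to be measured is compound 4, `Cc1ccc(OCC(=O)N(Cc2cccs2)c2ccn[nH]2)cc1`. Its change from compound 2 is a single one: 1H-pyrazol-5-yl in place of pyrimidin-2-yl on an amide-type nitrogen. For the measured compounds named here, no measured pair shows this particular change, so there is no reference step to lean on. The estimate for compound 4 is therefore a cautious one, a step from compound 2 of a 1.5-fold lower number from compound 2 to compound 4 (0.17 log units; within the scatter), which amounts to little more than the scatter, and compound 4 is expected at 2500 nM, somewhere between 700 nM and 9000 nM.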

Compound 4, half-maximal effective concentration: 0.2 nM
Compound 4: the middle estimate sits 13000-fold (4.10 log units) above what was measured, and the stated range ends above it.
By their numbers in this assay, from the lowest: compound 4; then compound 3; then compound 2.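

In this assay, putting 1H-pyrazol-5-yl in place of pyrimidin-2-yl on the amide-type nitrogen gives a 19000-fold lower number from compound 2 to compound 4 (4.27 log units; beyond the scatter), a large step for one change. The earlier compounds shown here differed in more than one place, whereas this pair shows that the group on this nitrogen can, on its own, move the number enormously. The entering ring is five-membered and has one hydrogen-bond donor, while the leaving ring is six-membered and has none, and this single pair cannot say which of these differences matters.

Nothing shown here accounts for the size of this step. As far as these compounds go, it also remains open how a phenyl or 1-methyl-1H-pyrazol-5-yl group on the same nitrogen would compare, and so whether the ring's nitrogen-bound hydrogen matters.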